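Pyridinylmethyl to thiophenylmethyl at the amine: next compound

This account rests on a few compounds, and the source may have more. Where it says the series, first, only, none or still open, it means among the compounds named here.

Measured so far in a functional assay on CHO cells for agonist activity at adenosine receptor A2b (Homo sapiens), read by scintillation counting and cAMP accumulation, with a stated time of 150 min, in the presence of a further agent that is not named here; a lower number here means a stronger inhibitor, a higher number a weaker inhibitor:
compound 1 `Nc1nc(NCc2cccnc2)nc2sc(-c3ccco3)nc12` gives 109 nM
compound 2 `Nc1nc(NCc2ccncc2)nc2sc(-c3ccco3)nc12` gives 33 nM
compound 3 `COc1cccc(CNc2nc(N)c3nc(-c4ccc(C)o4)sc3n2)c1` gives 120 nM

Compound 2 stands lowest of the three numbers in this assay. Its nearest neighbour is compound 1, with a 3.3-fold lower number from compound 1 to compound 2 (0.52 log units; beyond the scatter) separating them, a step beyond the scatter; compound 3 lies further up still. Among the measured compounds shown here, compound 3 differs from compound 2 in more than one place, so no single step between them is drawn.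

The next compound, compound 4 `Nc1nc(NCc2ccsc2)nc2sc(-c3ccco3)nc12`, changes compound 2 as follows: thiophen-3-yl in place of pyridin-4-yl on a saturated chain carbon bound to a nitrogen on an aromatic ring. For the measured compounds named here, the only measured step at this place is the one from compound 1 to compound 2, a modest shift when the ring nitrogen moves; no measured pair exchanges the six-membered ring for a five-membered one, so the direction of the present change is not read from the data. Given that the one step at this place was modest, compound 4 is estimated to stay near compound 2, expected at a 1.7-fold higher number from compound 2 to compound 4 (0.22 log units; within the scatter), most likely a small rise. For compound 4 the estimate in this assay is 55 nM, ranging from 18 nM to 180 nM.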

Compound 4, half-maximal inhibitory concentration: 8.96 nM
Compound 4: middle estimate off by 6.1-fold (0.79 log units), on the high side; measured number below the stated range.
By their numbers in this assay, from the lowest: compound 4; then compound 2; then compounds 1 and 3 (each within the scatter of the next).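

In this assay, thiophen-3-yl in place of pyridin-4-yl gives a 3.7-fold lower number from compound 2 to compound 4 (0.57 log units; beyond the scatter), and in place of pyridin-3-yl it gives a 12-fold lower number from compound 1 to compound 4 (1.09 log units; beyond the scatter), so a pyridine nitrogen is not required at this place on the saturated chain carbon, and a five-membered ring with sulfur as its hetero atom is tolerated. The exchange of ring type reaches a large step against compound 1, whereas moving the ring nitrogen alone gave only the modest 3.3-fold lower number from compound 1 to compound 2 (0.52 log units; beyond the scatter), so this place responds more widely than the pyridine pair showed. Nothing available explains the lower number of compound 4.

Whether this gain is specific to thiophen-3-yl remains open, as the compounds shown include neither thiophen-2-yl nor unsubstituted phenyl on the same core. Also open, on these data alone, is how a longer chain carrying the thiophen-3-yl group would read in this assay.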